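Methyl for Isopropyl on a Weakly Active Pyrazolopyridine Pair

The source may report more compounds than this note shows. Statements on the series, on what has been measured and on what is new or still open speak of the compounds shown alone.

Of the compounds shown here, two of a shared core have been measured in a functional assay on MCF7 cells (Homo sapiens) for inhibition, read by fluorescence, with a stated time of 72 h; on this read-out higher numbers stand for weaker inhibition of growth and lower numbers for stronger inhibition of growth. Compound 1 `Cc1nc(C2CC2)cc2nn(-c3ccccc3)cc12` gives 63500 nM in this assay. Compound 2 `CC(C)c1nc(-c2ccccc2)cc2nn(-c3ccccc3)cc12` gives 91000 nM in this assay, the highest of the two numbers, yet its nearest neighbour, compound 1, lies within the usual scatter of it, so the two values cannot be told apart. Both compounds sit in a range that marks only weak inhibition of growth.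

Compound 3 `Cc1nc(-c2ccccc2)cc2nn(-c3ccccc3)cc12` is not yet measured. It differs from compound 2 in one place: methyl in place of isopropyl on an aromatic carbon. Among the measured compounds shown here, no step between measured compounds is available for this change, and compound 1 differs from compound 2 in two places, so its value cannot be used to isolate the methyl for isopropyl exchange.

Given that compound 2 gives 91000 nM and compound 1 gives 63500 nM with both in the same weak region, compound 3 is expected to stay there, with an estimated step from compound 2 of a 1.2-fold lower number from compound 2 to compound 3 (0.08 log units; within the scatter) that would not reach beyond the scatter. Compound 3 is therefore estimated at 75000 nM, with a range from 30000 nM to 180000 nM.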

Compound 3, concentration for 50% growth inhibition: 11000 nM
Beside the measured number, compound 3's estimate is 6.8-fold (0.83 log units) above it; measured number outside the range, below it.
By their numbers in this assay, from the lowest: compound 3; then compounds 1 and 2 (each within the scatter of the next).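

In this assay the position next to the ring nitrogen proves sensitive to its substituent: methyl in place of isopropyl gives a clear gain in growth inhibition (an 8.3-fold lower number from compound 2 to compound 3 (0.92 log units; beyond the scatter)), a change that the two earlier compounds, which differ from each other in two places, could not isolate. The phenyl group also counts once methyl is present, since phenyl in place of cyclopropyl on an aromatic carbon gives a further clear gain (a 5.8-fold lower number from compound 1 to compound 3 (0.76 log units; beyond the scatter)), so compound 3, which carries both methyl and phenyl, stands apart from each of the other two compounds by a step beyond the scatter. Nothing in the data shown explains either step.

The compounds shown leave open whether the gain belongs to methyl itself or would also appear with hydrogen, an ethyl group or an amine on that carbon. They also leave open whether a methoxy group on the phenyl ring, or a pyridine ring in place of phenyl, would take growth inhibition further than compound 3 does.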